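Sulfonyl aryl exchange on the shared core

This account rests on a few compounds, and the source may have more. Where it says the series, first, only, none or still open, it means among the compounds named here.

Compound 1 `CNCc1cn(S(=O)(=O)c2cccs2)c(-c2cccnc2F)c1F` gives 0.54 in a physicochemical assay for lipophilicity, read by HPLC, at pH 7.4 (a higher number here means a more lipophilic compound, a lower number a more polar compound), and is the top of the two numbers measured, although compound 2 `CNCc1cn(S(=O)(=O)c2ccoc2)c(-c2cccnc2F)c1F` gives 0.45 and the step of a number 0.09 log units lower from compound 1 to compound 2 (within the scatter) lies within the scatter. Compound 3 `CNCc1cn(S(=O)(=O)c2cccc(F)n2)c(-c2cccnc2F)c1F` differs from compound 1 by 6-fluoropyridin-2-yl in place of thiophen-2-yl on a sulfonyl sulfur. Within the data shown here, the only measured step touching this position is a number 0.09 log units lower from compound 1 to compound 2 (within the scatter), and it swaps one five-membered ring for another; no measured step brings in a six-membered ring with a ring nitrogen and a fluorine. A downward step beyond the scatter is expected in this assay, namely a number 0.34 log units lower from compound 1 to compound 3 (beyond the scatter). Compound 3 is estimated at 0.2, with a range from -0.3 to 0.7.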

Compound 3, distribution coefficient: 0.7
Compound 3: middle estimate off by 0.50 log units, on the low side; the range from low to high includes it.
By their numbers in this assay, from the lowest: compounds 2, 1 and 3 (each within the scatter of the next).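

At the sulfonyl sulfur, a six-membered aromatic ring with a fluorine now joins the two five-membered rings, and this assay shows a number 0.16 log units higher from compound 1 to compound 3 (within the scatter) and a number 0.25 log units higher from compound 2 to compound 3 (within the scatter) for this change. The three aryl groups thus cannot be told apart in this assay, whatever the ring size. Nothing on hand offers an explanation for this reading. Going by these compounds, whether a carboxylic acid or an amine on the sulfonyl aryl ring would give a step beyond the scatter remains open. On these data alone, the separate contributions of the ring nitrogen and the fluorine also remain open.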